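The source may report more compounds than this note shows. Statements on the series, on what has been measured and on what is new or still open speak of the compounds shown alone.

Measured compounds in the series:

Compound 1 `CC[C@@H](Oc1ccccc1)C(=O)Nc1nc(-c2ccccc2)n[nH]1`: 1900 nM
Compound 2 `O=C(COc1ccccc1)Nc1nc(-c2ccc(F)cc2)n[nH]1`: 1500 nM
Compound 3 `Cc1ccc(C(=O)Nc2nc(-c3ccccc3)n[nH]2)cc1`: 100 nM

The three measured compounds share a core and differ in the acyl group on the amide. In an assay on CHO cells for displacement of a labelled ligand from adenosine receptor A3 (Homo sapiens), read by scintillation counting, with a stated time of 60 min (a lower number here means a stronger inhibitor, a higher number a weaker inhibitor), compound 1 gives 1900 nM and compound 2 gives 1500 nM; both carry an aryloxy-alkanoyl amide. Compound 3, with a 4-methylbenzoyl amide, gives 100 nM in this assay, the lowest number of the three. Its gap to compound 2 is well beyond the scatter, and the gap to compound 1 is wider still, so on these numbers compound 3 is the strongest inhibitor of the set.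

The next compound, compound 4 `O=C(Nc1nc(-c2ccccc2)n[nH]1)c1ccc(Cl)cc1`, keeps the benzoyl amide of compound 3 and makes one change: chloro in place of methyl on an aromatic carbon. Among the compounds with values here, no step between two measured compounds covers this kind of exchange, so no measured precedent exists. Both groups are single heavy atoms with no donors or acceptors, and the benzoyl amide that gives compound 3 its 100 nM is retained. The expected step in this assay is therefore small, in either direction, and most likely within the scatter; a modest improvement is as plausible as a modest loss. Compound 4 is expected to give about 90 nM in this assay, with a range of 30 nM to 300 nM; the step from compound 3 to compound 4 is estimated as a 1.1-fold lower number from compound 3 to compound 4 (0.05 log units; within the scatter).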

Compound 4, inhibition constant: 200 nM
Estimate against measurement, compound 4: 2.2-fold (0.35 log units) below, and the stated range covers the measured number.
By their numbers in this assay, from the lowest: compounds 3 and 4 (each within the scatter of the next); then compounds 2 and 1 (each within the scatter of the next).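

In this assay, within the data shown here, chloro in place of methyl on an aromatic carbon, para to a large group, gives a 2.0-fold higher number from compound 3 to compound 4 (0.30 log units; within the scatter) and is the first step that changes a single place. At this position, 4-methylphenyl and 4-chlorophenyl therefore cannot be told apart, and the low number of compound 3 does not depend on methyl specifically, since a chlorine serves equally well within the scatter. No measurement bears on why the two groups read alike.

Open, going by these compounds, is whether this position responds to anything beyond these two single-atom groups: plain hydrogen would show whether a group is needed here at all, while an amine, a carboxylic acid or a longer chain such as butyl would test how far the exchange can go before the number moves beyond the scatter. Also open is how the acyl group and the aryl group on the other side of the shared core each contribute, as the compounds shown offer no single-place step for either.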